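The compounds below may be only part of what the source reports. "The series", "measured", "known", "first", "only" and "open" are said of these compounds alone.

Measured so far in a functional assay on PANC-1 cells (Homo sapiens) for inhibition, read by MTT assay, with a stated time of 72 h; a higher number here means a weaker inhibitor of growth, a lower number a stronger inhibitor of growth:
compound 1, `COc1cccc(CNCCCNS(=O)(=O)c2cc(C(F)(F)F)cc(C(F)(F)F)c2)c1`, gives 10000 nM
compound 2, `O=S(=O)(NCCCNCc1cccc(Cl)c1)c1cc(C(F)(F)F)cc(C(F)(F)F)c1`, gives 12000 nM
compound 3, `O=S(=O)(NCCCNCc1ccc(Cl)c(C(F)(F)F)c1)c1cc(C(F)(F)F)cc(C(F)(F)F)c1`, gives 10000 nM

The three compounds share one core and differ only in the aryl group on the saturated chain carbon bound to the amine nitrogen. Compound 3 stands level with compound 1 at the digits shown, and these two together carry the lowest numbers of the three; compound 2 is the furthest from compound 3, the difference being a 1.2-fold lower number from compound 2 to compound 3 (0.08 log units; within the scatter), which is within the scatter.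

Compound 4, `O=S(=O)(NCCCNCc1ccc(Cl)c(Cl)c1)c1cc(C(F)(F)F)cc(C(F)(F)F)c1`, has not yet been measured in this assay. It differs from compound 3 by chloro in place of trifluoromethyl on an aromatic carbon. Going by the values given here, no measured step replaces a trifluoromethyl with a chloro directly. Among the compounds with values here, the steps that bear on it are the other exchanges on this same aryl group: a 1.2-fold higher number from compound 1 to compound 2 (0.08 log units; within the scatter), no change at the digits printed from compound 1 to compound 3 (within the scatter) and a 1.2-fold lower number from compound 2 to compound 3 (0.08 log units; within the scatter), every one of them within the scatter. On that basis the step is expected to be no change at the digits printed from compound 3 to compound 4 (within the scatter), nothing beyond the scatter. Compound 4 is therefore estimated at 10000 nM, with a range from 5000 nM to 20000 nM.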

Compound 4, concentration for 50% growth inhibition: 5600 nM
The estimate for compound 4 lay 1.8-fold (0.25 log units) above the measured number; the range from low to high includes it.
By their numbers in this assay, from the lowest: compounds 4, 1, 3 and 2 (each within the scatter of the next, the first and the last beyond it).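

In this assay, going by these compounds alone, chloro in place of hydrogen on an aromatic carbon, which turns 3-chlorophenyl into 3,4-dichlorophenyl, gives a 2.1-fold lower number from compound 2 to compound 4 (0.33 log units; beyond the scatter) and so provides the first step in this set that lies beyond the scatter, though only modestly. Chloro in place of trifluoromethyl gives a 1.8-fold lower number from compound 3 to compound 4 (0.25 log units; within the scatter) and 3,4-dichlorophenyl in place of 3-methoxyphenyl gives a 1.8-fold lower number from compound 1 to compound 4 (0.25 log units; within the scatter), so compound 4 cannot be separated from compound 3 or from compound 1. Nothing given here accounts for these steps.

The compounds shown leave open whether a bromo or nitrile group on this aromatic ring would carry the step from compound 2 any further. They also leave open how a longer chain between the two nitrogens would read alongside the 3,4-dichlorophenyl group.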